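This account rests on a few compounds, and the source may have more. Where it says the series, first, only, none or still open, it means among the compounds named here.

In an ADME assay on HEK293 cells (Homo sapiens) for cytotoxicity, read by MTT assay, with a stated time of 72 h (on this read-out lower numbers stand for stronger inhibition and higher numbers for weaker inhibition), compound 1 `O=C(CN1CCN(C(=O)c2ccccc2)CC1)N1CCN(CCCc2c[nH]c3ccccc23)CC1` gives > 200000 nM, which is a limit of the assay and not a number. Compound 2 `O=C(CN1CCN(C(=O)c2ccc(Cl)cc2)CC1)N1CCN(CCCc2c[nH]c3ccccc23)CC1` gives 98200 nM and compound 3 `O=C(CN1CCN(C(=O)c2ccccc2)CC1)N1CCN(CCCc2c[nH]c3ccc(F)cc23)CC1` gives 148000 nM, two values within the scatter of each other. Compound 4 `O=C(CN1CCN(C(=O)c2ccc(Cl)cc2)CC1)N1CCN(CCCc2c[nH]c3ccc(F)cc23)CC1` differs from compound 3 by one change, phenyl to 4-chlorophenyl: chloro in place of hydrogen on an aromatic carbon. For the measured compounds named here, the closest precedent is the identical change measured as an at least 2.0-fold lower number from compound 1 to compound 2 (0.30 log units; that floor lies within the scatter). A different change, fluoro in place of hydrogen on an aromatic carbon, gave an at least 1.3-fold lower number from compound 1 to compound 3 (0.13 log units; that floor lies within the scatter) and bears on it less directly. In this assay, a similar modest lowering is therefore expected, an estimated 2.1-fold lower number from compound 3 to compound 4 (0.33 log units; beyond the scatter). Compound 4 is estimated at 70000 nM, with an expected range of 35000 nM to 140000 nM.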

Compound 4, half-maximal inhibitory concentration: 44500 nM
For compound 4 the middle estimate is 1.6-fold (0.20 log units) above the measured one; measured number inside the range.
By their numbers in this assay, from the lowest: compound 4; then compounds 2 and 3 (each within the scatter of the next). At a limit, above all of these: compound 1.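

For the compounds shown here, compound 1 sits at a limit, so the earlier steps gave only floors; in this assay, the steps to compound 4 are the first full measurements of these changes. Chloro in place of hydrogen on the aromatic carbon gives a 3.3-fold lower number from compound 3 to compound 4 (0.52 log units; beyond the scatter), and fluoro in place of hydrogen gives a 2.2-fold lower number from compound 2 to compound 4 (0.34 log units; beyond the scatter). Whether the chloro step matches the earlier one stays unsettled: the same change on two cores in this assay, an at least 2.0-fold lower number (0.30 log units; that floor lies within the scatter) from compound 1 to compound 2 and a 3.3-fold lower number (0.52 log units; beyond the scatter) from compound 3 to compound 4; the limit leaves it open whether they differ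

The compounds shown leave open whether other groups on this carbon, such as a methoxy group or an amine, would also lower the number.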